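Adding a Single Fluorine to a Benzyl Amide

The source may hold more compounds than are shown below. What is called first, only, known or untested is meant among the compounds shown, and "the series" means these compounds.

Two compounds share one core here. Compound 1 `CC(C(=O)NCc1cccc(Cl)c1)N1C(=O)CCC1=O` was run in a functional assay on the whole organism (strain Albino Swiss CD1) with Mus musculus as the target (a higher number here means that more compound is needed for the effect, a lower number that less compound is needed), but no result was reported for compound 1: its entry reads "not determined" (no result reported). For the measured compounds named here, compound 2 `CCC(C(=O)NCc1ccccc1)N1C(=O)CCC1=O` is the only compound with a number: in this assay compound 2 gives 90.3 mg/kg, and since nothing else carries a value, it stands alone and cannot be ranked against any neighbour. Compound 3 `CCC(C(=O)NCc1ccccc1F)N1C(=O)CCC1=O` differs from compound 2 in one place: fluoro in place of hydrogen on an aromatic carbon. It is still to be measured in this assay. Going by the values given here, no pair of measured compounds shows what such a change does, so the expectation rests on compound 2 alone. A change this small, a fluoro in place of a hydrogen on an aromatic carbon ortho to a large group, is expected to move the dose little, probably no further than the scatter of repeated measurements, in either direction. The step from compound 2 to compound 3 is therefore estimated at a 1.1-fold lower number from compound 2 to compound 3 (0.05 log units; within the scatter). For compound 3 the estimated dose is 80 mg/kg, with a range from 35 mg/kg to 180 mg/kg.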

Compound 3, dose for half-maximal effect: 65.7 mg/kg
For compound 3 the middle estimate is 1.2-fold (0.09 log units) above the measured one; the range from low to high includes it.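

For the compounds shown here, this is the first measured step at this position, and it shows that a fluoro can stand on an aromatic carbon ortho to a large group, the change from phenyl to 2-fluorophenyl, without a clear shift in the dose needed in this assay (a 1.4-fold lower number from compound 2 to compound 3 (0.14 log units; within the scatter)). Compound 2 and compound 3 therefore cannot be told apart in this whole-animal test, so this one position accepts this one small atom, although a single pair cannot show a trend. Nothing available here accounts for the result or tests what the fluoro does in the animal.

The compounds shown leave open whether a larger group in the same place, such as a methoxy, a trifluoromethyl or an amine, would keep the dose in the same range or move it well beyond the scatter. They also leave open whether a fluoro elsewhere on the aromatic ring, or a longer chain on the shared core, would change the dose more than this hydrogen-to-fluoro exchange did.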